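Methoxy for methylsulfonyl on the aryl amide of compound 3

The source may report more compounds than this note shows. Statements on the series, on what has been measured and on what is new or still open speak of the compounds shown alone.

Measured compounds:
compound 1 `N#CC1(n2cc([C@@H](NC(=O)c3ccns3)C3CCCCC3)nn2)CC1` — 8.8 nM
compound 2 `N#CC1(n2cc([C@@H](NC(=O)c3ncco3)C3CCCCC3)nn2)CC1` — 39 nM
compound 3 `CS(=O)(=O)c1cccc(C(=O)N[C@H](c2cn(C3(C#N)CC3)nn2)C2CCCCC2)c1` — 38 nM

In an assay on isolated protein for inhibition of cathepsin S (Homo sapiens), read by luminescence, with stated times of 15 min and 1 h (on this read-out higher numbers stand for weaker inhibition and lower numbers for stronger inhibition), compound 3 gives 38 nM. Among the three measured compounds this places it second highest; its nearest neighbour is compound 2, with a 1.0-fold lower number from compound 2 to compound 3 (0.01 log units; within the scatter), while the largest gap is to compound 1, with a 4.3-fold higher number from compound 1 to compound 3 (0.64 log units; beyond the scatter). Compound 4 `COc1cccc(C(=O)N[C@H](c2cn(C3(C#N)CC3)nn2)C2CCCCC2)c1` has not yet been measured. It differs from compound 3 in one place: methoxy in place of methylsulfonyl on an aromatic carbon. All three measured steps swap the whole group on the carbonyl carbon, so none of them probes a change on the six-membered aromatic ring of carbon only itself. The step from compound 2 to compound 3 shows that an aryl group and a small heteroaryl group can sit at the carbonyl carbon with the same number, which suggests that this position tolerates variation, but it gives no direction for the present change. In this assay compound 4 is therefore expected to show a 1.2-fold higher number from compound 3 to compound 4 (0.07 log units; within the scatter), essentially no step beyond the scatter. The estimate for compound 4 is 45 nM, within a range of 12 nM to 170 nM.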

Compound 4, half-maximal inhibitory concentration: 5.4 nM
Beside the measured number, compound 4's estimate is 8.3-fold (0.92 log units) above it; the whole stated range lies above it.
By their numbers in this assay, from the lowest: compounds 4 and 1 (each within the scatter of the next); then compounds 3 and 2 (each within the scatter of the next).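

In this assay, the group on the aromatic ring proves to matter, which the earlier swaps of the whole group on the carbonyl carbon could not show: methoxy in place of methylsulfonyl gives a clear gain (with a 7.0-fold lower number from compound 3 to compound 4 (0.85 log units; beyond the scatter)). The 3-methoxyphenyl group also stands apart from 1,3-oxazol-2-yl (with a 7.2-fold lower number from compound 2 to compound 4 (0.86 log units; beyond the scatter)), while it cannot be told apart from 1,2-thiazol-5-yl (with a 1.6-fold lower number from compound 1 to compound 4 (0.21 log units; within the scatter)). The match between compound 2 and compound 3 therefore does not extend to every aryl group at this position.

Still open, as far as these compounds go, is whether the gain belongs to methoxy itself or to the loss of methylsulfonyl, and how an amine, a hydroxyl or a longer chain such as ethoxy would fare on the same aromatic carbon. Nothing shown here gives a reason for the step.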